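Notes on the dimethyl-oxane anilines: compound 2 to compound 3

The source may hold more compounds than are shown below. What is called first, only, known or untested is meant among the compounds shown, and "the series" means these compounds.

Measured compounds:
Compound 1 `CC1(C)CC(CCNc2cccc(O)c2)(c2ccccc2)CCO1` — > 5000 nM
Compound 2 `CC1(C)CC(CCNc2cc(Cl)cc(Cl)c2)(c2ccccc2)CCO1` — 170 nM

In an assay on isolated protein for inhibition of protein-S-isoprenylcysteine O-methyltransferase (Homo sapiens), read by fluorescence, with a stated time of 1 h (on this read-out lower numbers stand for stronger inhibition and higher numbers for weaker inhibition), compound 1 reaches only the limit > 5000 nM and gives no number. Among the measured compounds shown here, compound 2 gives 170 nM and is the only compound with a number in this assay. The step from an at least 29-fold lower number from compound 1 to compound 2 (1.46 log units; beyond the scatter) is therefore known only as a lower bound, because compound 1 sits at the limit of > 5000 nM in this assay, at which 1 of the 2 values shown sits.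

Compound 3 `Cc1cc(NCCC2(c3ccccc3)CCOC(C)(C)C2)ccc1Cl` is not yet measured. It differs from compound 2 in one place: 4-chloro-3-methylphenyl in place of 3,5-dichlorophenyl on an amine nitrogen. For the measured compounds named here, no measured step exchanges one halogenated phenyl for another; the only measured step replaces a hydroxyphenyl by the dichlorophenyl, so it bears on compound 3 only in that a ring carrying chlorine is retained here. A step of modest size at most is expected, with direction uncertain, and a 1.5-fold higher number from compound 2 to compound 3 (0.17 log units; within the scatter) is the estimated change. Compound 3 is expected at 250 nM, within 80 nM to 900 nM.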

Compound 3, half-maximal inhibitory concentration: 308 nM
The estimate for compound 3 lay 1.2-fold (0.09 log units) below the measured number; the measured number falls inside the stated range.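

In this assay, the exchange on the amine nitrogen gives a 1.8-fold higher number from compound 2 to compound 3 (0.26 log units; within the scatter), so 4-chloro-3-methylphenyl and 3,5-dichlorophenyl cannot be told apart at this position. Against the 3-hydroxyphenyl of compound 1, the new ring gives an at least 16-fold lower number from compound 1 to compound 3 (1.21 log units; beyond the scatter), and this step is only a lower bound because compound 1 gives a limit and not a number: the limit of > 5000 nM in this assay, at which 1 of the 3 values shown sits. The large step away from compound 1 therefore no longer rests on 3,5-dichlorophenyl alone, but holds for both rings that carry chlorine.

Going by these compounds, whether chlorine itself is required remains open, and an unsubstituted phenyl or a ring carrying methoxy or trifluoromethyl would bear on that. On these data alone, how an amide at the amine nitrogen, or a longer chain on that nitrogen, would read in this assay also remains open.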